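A trimethoxyphenyl swap in a cell tolerance test

A few compounds are considered here, and "the series" means these few. Any claim that something is new, unique, unknown or untested is made for them only; others in the source may bear on it.

In an ADME assay on HEK-293T cells (Homo sapiens) for cytotoxicity, read by MTT assay, with a stated time of 48 h (a lower number here means that less compound is tolerated, a higher number that more compound is tolerated), compound 1 (`COc1ccc(C(=O)N2N=C(c3ccccc3)CC2c2cn(C)c3ccccc23)cn1`) gives > 300000 nM as a limit, not a number. Compound 2 (`COc1ccc2c(c1)c(C1CC(c3ccccc3)=NN1C(=O)c1ccc(OC)nc1)cn2C`) gives > 300000 nM as a limit too. Compound 3 (`COc1ccc2c(c1)c(C1CC(c3ccc(Cl)cc3)=NN1C(=O)c1ccc(OC)nc1)cn2C`) also stands at > 300000 nM as a limit, so no number exists for it. Compound 4 (`COc1ccc2c(c1)c(C1CC(c3cc(OC)c(OC)c(OC)c3)=NN1C(=O)c1ccc(OC)nc1)cn2C`) differs from compound 3 in one group, and 3,4,5-trimethoxyphenyl in place of 4-chlorophenyl on a carbon with a double bond to nitrogen counts that change: 3,4,5-trimethoxyphenyl in place of 4-chlorophenyl on a carbon with a double bond to nitrogen.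

Two measured changes bear on it. The chloro in place of hydrogen gave a step that the two limits leave unreadable from compound 2 to compound 3 and the methoxy in place of hydrogen gave a step that the two limits leave unreadable from compound 1 to compound 2 so neither offers a size to carry over. Among the measured compounds shown here, all that can be drawn on is the limit of > 300000 nM in this assay, at which 3 of the 3 values shown sit, and no compound so far has a number. In this assay no step beyond the usual scatter is therefore expected, in either direction. The expected step is a number no higher from compound 3 to compound 4 (the limit leaves the size open) in size. For compound 4 the estimate is 300000 nM with 100000 nM to 600000 nM as its expected range.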

Compound 4, half-maximal cytotoxic concentration: > 300000 nM
Compound 4: a limit, no number (the forecaster's own chance of this, stated with the estimate: 75%); the middle value sits exactly at the limit.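

Compound 4 gives a limit and not a number, as do compound 2 and compound 3, so no step among these compounds can be read. What stays open in this assay is the concentration at which any of them stops being tolerated: the limit of > 300000 nM in this assay, at which 4 of the 4 values shown sit.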